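The source may hold more compounds than are shown below. What is called first, only, known or untested is meant among the compounds shown, and "the series" means these compounds.

Measured so far:
compound 1, `Brc1ccc(C(c2c[nH]c3ccc(Br)cc23)c2c[nH]c3ccc(Br)cc23)cc1` — 1500 nM
compound 2, `O=[N+]([O-])c1ccc(C(c2c[nH]c3ccc(Br)cc23)c2c[nH]c3ccc(Br)cc23)cc1` — 1500 nM
compound 3, `OC[C@H]1O[C@@H](n2cc(C(c3ccc(Br)cc3)c3cn([C@@H]4O[C@H](CO)[C@@H](O)[C@H](O)[C@H]4O)c4ccc(Br)cc34)c3cc(Br)ccc32)[C@H](O)[C@@H](O)[C@@H]1O` — 27000 nM

All three compounds were tested in a functional assay on HeLa cells (Homo sapiens) for inhibition, read by MTT assay, with a stated time of 48 h; a higher number here means a weaker inhibitor, a lower number a stronger inhibitor. Compound 1 and compound 2 share one core and differ by a single change, (nitro in place of bromo on an aromatic carbon). In this assay the step of no change at the digits printed from compound 1 to compound 2 (within the scatter), so this change alone left the reading where it was. Compound 3 is built on another core; the difference between the core of compound 1 and the core of compound 3 is not broken down here. What the two values show is that compound 3 gives a much higher number than compound 1, and that gap lies beyond the usual scatter.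

Compound 4, `O=[N+]([O-])c1ccc(C(c2cn([C@@H]3O[C@H](CO)[C@@H](O)[C@H](O)[C@H]3O)c3ccc(Br)cc23)c2cn([C@@H]3O[C@H](CO)[C@@H](O)[C@H](O)[C@H]3O)c3ccc(Br)cc23)cc1`, has not yet been measured. For the measured compounds named here, it is related to compound 3 by the change (nitro in place of bromo on an aromatic carbon), which is the same change as the one between compound 1 and compound 2, made at the same place. The expected step from compound 3 to compound 4 is accordingly no change at the digits printed from compound 3 to compound 4 (within the scatter), an expectation that rests on compound 1 and compound 2 because no change at the digits printed from compound 1 to compound 2 (within the scatter). As the change is carried over to a different core, this expectation is less firm than the measured pair itself. For compound 4 the estimated value in this assay is 27000 nM, with a likely range from 12000 nM to 60000 nM.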

Compound 4, half-maximal inhibitory concentration: 30000 nM
Compound 4: the middle estimate sits 1.1-fold (0.05 log units) below what was measured, and the stated range covers the measured number.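

In this assay, putting nitro in place of bromo on the second core gives a 1.1-fold higher number from compound 3 to compound 4 (0.05 log units; within the scatter), so the reading stays where it was, just as it did on the first core. Set side by side, the two steps agree, and in this small set the swap carries from one core to the other without a detectable difference: the same change on two cores in this assay, no change at the digits printed (within the scatter) from compound 1 to compound 2 and a 1.1-fold higher number (0.05 log units; within the scatter) from compound 3 to compound 4, 1.1-fold (0.05 log units) apart, within the scatter of two such steps

For the compounds shown here, this agreement rests on only two pairs, both reporting the same swap at the same place in a single cell assay, so it does not show that the result would hold on a third core or that other changes would transfer in the same way; and since neither step moved the reading beyond the scatter, the pairs cannot test whether a change with a clear effect on one core would keep that effect on the other, nor do they explain why the swap leaves the reading in place.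

The compounds shown leave open what an amine, a carboxylic acid or a methoxy group would do in this place on either core. Going by these compounds alone, they also leave open which part of the difference between the two cores goes with the gap in their readings, as no single-change pair here connects them.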